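This account rests on a few compounds, and the source may have more. Where it says the series, first, only, none or still open, it means among the compounds named here.

Compound 3 `C#CCNc1nc(N)nc2c1ncn2[C@H]1C[C@H](N=[N+]=[N-])[C@@H](CO)O1` belongs to a small set built on a shared core, alongside compound 1 `CN(C)c1nc(N)nc2c1ncn2[C@H]1C[C@H](N=[N+]=[N-])[C@@H](CO)O1` and compound 2 `[N-]=[N+]=N[C@H]1C[C@H](n2cnc3c(NC4CC4)nc(N)nc32)O[C@@H]1CO`. In an ADME assay on PBMC cells (Homo sapiens) for cytotoxicity, with a stated time of 5 days (on this read-out lower numbers stand for stronger inhibition and higher numbers for weaker inhibition), compound 1 gives > 100000 nM, which is a limit of the assay and not a number. In this assay compound 2 gives > 100000 nM, again a limit. In this assay compound 3 gives > 100000 nM, also a limit. Compound 3 thus stands at the limit of > 100000 nM in this assay, at which 3 of the 3 values shown sit, together with both of its measured companions. The step that the two limits leave unreadable from compound 1 to compound 2, the step that the two limits leave unreadable from compound 1 to compound 3 and the step that the two limits leave unreadable from compound 2 to compound 3 consequently have no readable size.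

Compound 4 `C=CCN(C)c1nc(N)nc2c1ncn2[C@H]1C[C@H](N=[N+]=[N-])[C@@H](CO)O1` has not yet been measured; it differs from compound 3 by allyl(methyl)amino in place of propargylamino on an aromatic carbon. For the measured compounds named here, because every measured value sits at the limit of > 100000 nM in this assay, at which 3 of the 3 values shown sit, none of the measured steps can be sized, and the step of a number no higher from compound 3 to compound 4 (the limit leaves the size open) is expected to show nothing beyond the scatter. Compound 4 is therefore expected to give 100000 nM in this assay, with a range from 30000 nM to 100000 nM, and most probably to return a limit once more.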

Compound 4, half-maximal inhibitory concentration: > 100000 nM
Compound 4: a limit, no number; the forecaster's own chance of this, stated with the estimate: 85%; the middle value sits exactly at the limit.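

For the compounds shown here, no step from compound 1, compound 2 or compound 3 to compound 4 can be read in this assay, as all four compounds sit at one limit: the limit of > 100000 nM in this assay, at which 4 of the 4 values shown sit. The compounds shown leave open at what concentration, if any, each would inhibit these cells, and whether the changes between them alter that concentration.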